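This account rests on a few compounds, and the source may have more. Where it says the series, first, only, none or still open, it means among the compounds named here.

Measured compounds:
- compound 1 `Cc1nc(-c2ccccc2)sc1C(=O)CSc1nc(-c2ccc(Cl)c(Cl)c2)c(C#N)c(=O)[nH]1` — in a functional assay on U-87MG ATCC cells for antiproliferative activity against U-87 MG (Homo sapiens), read by MTT assay, with a stated time of 48 h, tested at 5 uM (a higher number here means a weaker effect of the compound at the concentration tested, a lower number a stronger effect), compound 1 gives 98.6%
- compound 2 `Cc1nc(-c2ccccc2)sc1C(=O)CSc1nc(-c2cccc(Cl)c2)c(C#N)c(=O)[nH]1` — in this assay compound 2 gives 86.9%

For the measured compounds named here, of the two numbers so far, compound 2 stands at the lower end, and its nearest neighbour is compound 1, which sits a number 11.7 percentage points lower from compound 1 to compound 2 (beyond the scatter). That single step, hydrogen in place of chloro on an aromatic carbon, is the only one recorded, and it is modest in size while lying beyond the scatter.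

The next compound, compound 3 `Cc1nc(-c2ccccc2)sc1C(=O)CSc1nc(-c2ccccc2)c(C#N)c(=O)[nH]1`, has not yet been tested. It differs from compound 2 by hydrogen in place of chloro on an aromatic carbon. Going by the values given here, this is the same kind of change as the one from compound 1 to compound 2, now applied to the chloro that remains. Among the compounds with values here, only that one step bears on the question; whether a second removal of chloro carries the number the same way cannot be read from one example, so the expectation is loose.

Compound 3 is expected to show a further lowering in this assay of about a number 6.9 percentage points lower from compound 2 to compound 3 (within the scatter), in the same direction as before. The estimate for compound 3 is therefore 80%, within a range from 62% to 97%.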

Compound 3, a percentage reported as activity, at one concentration (the size of the read-out at that concentration, not a potency): 92.1%
Compound 3: middle estimate off by 12.1 percentage points, on the low side; measured number inside the range.
By their numbers in this assay, from the lowest: compounds 2, 3 and 1 (each within the scatter of the next, the first and the last beyond it).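

In this assay, the change from 3-chlorophenyl to phenyl gives a number 5.2 percentage points higher from compound 2 to compound 3 (within the scatter), so the replacement of chloro by hydrogen, which earlier gave a number 11.7 percentage points lower from compound 1 to compound 2 (beyond the scatter), does not repeat that step beyond the scatter when applied to the remaining chloro. Phenyl in place of 3,4-dichlorophenyl gives a number 6.5 percentage points lower from compound 1 to compound 3 (within the scatter), so the compound with no chloro on this ring cannot be told apart from the one with two, while compound 2, with one chloro, stands within the scatter of compound 3 but beyond it from compound 1; the three compounds therefore show no steady trend with the number of chloro groups on this ring. Nothing available accounts for this uneven behaviour at the position.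

The compounds shown leave open whether a group other than chloro, such as a methoxy group, an amine or a carboxylic acid, on this six-membered aromatic ring would move the number beyond the scatter of compound 3. They also leave open whether the same replacement of chloro by hydrogen would give a similar result if the rest of the shared core were different.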